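The source may hold more compounds than are shown below. What is called first, only, known or untested is meant among the compounds shown, and "the series" means these compounds.

The measured compounds:
compound 1, `CC/C=C/C(=O)Nc1cc2c(N3CCc4ccccc43)ncnc2cc1O[C@@H]1CCOC1`, gives 10900 nM in a functional assay on A549 cells (Homo sapiens) for antiproliferative activity, read by MTT assay, with a stated time of 72 h; on this read-out lower numbers stand for stronger inhibition and higher numbers for weaker inhibition;
compound 2, `CC(C)/C=C/C(=O)Nc1cc2c(N3CCc4ccccc43)ncnc2cc1O[C@@H]1CCOC1`, gives 8520 nM in this assay;
compound 3, `CC/C=C/C(=O)Nc1cc2c(N3CCCc4ccccc43)ncnc2cc1OC`, gives 5030 nM in this assay.

Compound 4, `COc1cc2ncnc(N3CCCc4ccccc43)c2cc1NC(=O)/C=C/C(C)C`, has not yet been measured. Compound 2 differs from compound 1 by methyl in place of hydrogen on a saturated chain carbon bound to a double-bonded chain carbon and a saturated chain carbon, and this change made a 1.3-fold lower number from compound 1 to compound 2 (0.11 log units; within the scatter). Compound 4 differs from compound 3 by methyl in place of hydrogen on a saturated chain carbon bound to a double-bonded chain carbon and a saturated chain carbon, the same change at the same place. The cores of compound 1 and compound 3 differ, but that difference is not broken down here. The expected step is a 1.3-fold lower number from compound 3 to compound 4 (0.10 log units; within the scatter), beside the measured 1.3-fold lower number from compound 1 to compound 2 (0.11 log units; within the scatter); this rests on the earlier step of a 1.3-fold lower number from compound 1 to compound 2 (0.11 log units; within the scatter) having stayed within the scatter, so only a small shift is expected. Compound 4 is therefore estimated at 4000 nM, with a likely range from 2000 nM to 8000 nM.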

Compound 4, half-maximal inhibitory concentration: 3450 nM
For compound 4 the middle estimate is 1.2-fold (0.06 log units) above the measured one, and the stated range covers the measured number.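

In this assay, replacing ethyl with isopropyl on the core of compound 3 gives a 1.5-fold lower number from compound 3 to compound 4 (0.16 log units; within the scatter), a shift too small to count as a real change. Set beside the same change on the core of compound 1, the two steps agree: the same change on two cores in this assay, a 1.3-fold lower number (0.11 log units; within the scatter) from compound 1 to compound 2 and a 1.5-fold lower number (0.16 log units; within the scatter) from compound 3 to compound 4, 1.1-fold (0.06 log units) apart, within the scatter of two such steps. This shows that the change stayed small on both of these cores, but it does not show that a larger effect would carry from one core to another, and two cores cannot establish a rule for the whole series.

The compounds shown leave open what a larger group, such as tert-butyl, or an amine at the same saturated chain carbon would do. As far as these compounds go, whether such a group would give a step beyond the scatter, and whether that step would match on both cores, also remains open.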